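Swapping Cyclopentyl for Phenyl on a Saturated Ring Carbon

A few compounds are considered here, and "the series" means these few. Any claim that something is new, unique, unknown or untested is made for them only; others in the source may bear on it.

Compound 1 `CC1=C(C(=O)OC(C)C)C(C2CCCC2)N/C(=N/C#N)N1` and compound 2 `CC1=C(C(=O)OC(C)C)C(c2ccccc2)N/C(=N/C#N)N1` share one core and differ in a single group. In an assay on cells for displacement of a labelled ligand from adenosine receptor A1 (Homo sapiens), with a stated time of 60 min, tested at 1 uM (on this read-out lower numbers stand for less inhibition and higher numbers for more inhibition at the one concentration tested (going by the name of the read-out)), compound 1 gives 3%, while compound 2 gives 20%. The structural change between them is phenyl in place of cyclopentyl on a saturated ring carbon and the measured step is a number 17 percentage points higher from compound 1 to compound 2 (beyond the scatter). Within the data shown here, one such pair is too little to call a rule, but it is the only direct guide available here.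

Compound 3 `CC1=C(C(=O)OC(C)C)C(C2CCCC2)NC(=O)N1` carries the same cyclopentyl group as compound 1 on a core that differs elsewhere; the difference between the two cores is not broken down here. In this assay compound 3 gives 1%, a value that lies within the scatter of compound 1.

Compound 4 `CC1=C(C(=O)OC(C)C)C(c2ccccc2)NC(=O)N1` has not yet been measured. It differs from compound 3 by phenyl in place of cyclopentyl on a saturated ring carbon, the same change that took compound 1 to compound 2, at the same place in the ring. The expected step is a number 15 percentage points higher from compound 3 to compound 4 (beyond the scatter), because the matching change gave a number 17 percentage points higher from compound 1 to compound 2 (beyond the scatter). Since the step rests on one example and the starting value of compound 3 is low, the range is kept wide. Compound 4 is expected to reach about 16%, most likely between 2% and 34%.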

Compound 4, a percentage reported as inhibition, at one concentration (the size of the read-out at that concentration, not a potency): 2%
For compound 4 the middle estimate is 14 percentage points above the measured one; the measured number falls inside the stated range.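

On the second core, phenyl in place of cyclopentyl on a saturated ring carbon gives, in this assay, a number 1 percentage points higher from compound 3 to compound 4 (within the scatter), so the swap leaves the reading essentially unmoved there. Setting this result beside the step on the first core shows that the two steps really do differ: the same change on two cores in this assay, a number 17 percentage points higher (beyond the scatter) from compound 1 to compound 2 and a number 1 percentage points higher (within the scatter) from compound 3 to compound 4, 16 percentage points apart, beyond the scatter of two such steps. The change therefore does not carry over with the same size from one core to the other in this series, although two pairs show only that the outcome can depend on the core, not why it does or how the swap would behave on any further core.

Going by these compounds, only cyclopentyl and phenyl appear on that saturated ring carbon, so it remains open how a longer chain, an amine or a carboxylic acid at the same place would read on either core, and whether another ester in place of the isopropoxycarbonyl group would alter the picture. Each number also comes from a single tested concentration at one receptor, which leaves open how potent any of these compounds is and how they would behave at other receptors.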